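The source may report more compounds than this note shows. Statements on the series, on what has been measured and on what is new or still open speak of the compounds shown alone.

Measured so far in a functional assay (spleen, spleen) for activation, with Mus musculus as the target; a lower number here means that less compound is needed, a higher number that more compound is needed for the effect:
compound 1, `CCSc1nc(N)c2nc(O)n(Cc3ccccc3)c2n1`, gives 0.1 uM
compound 2, `CCCSc1nc(N)c2nc(O)n(Cc3ccccc3)c2n1`, gives 0.01 uM
compound 3, `Nc1ncnc2c1nc(O)n2Cc1ccc(Cl)cc1`, gives 10 uM

Compound 1 stands second highest of the three numbers; its nearest neighbour is compound 2 at a lower number, and its furthest is compound 3, whose number lies far higher. For the measured compounds named here, the one step between measured compounds that differ in a single place runs from compound 1 to compound 2: a 10-fold lower number from compound 1 to compound 2 (1.00 log units; beyond the scatter). The pair of compound 1 and compound 3 differ in more than one place, so only the two values themselves are on record.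

The unmeasured compound 4, `CCCCSc1nc(N)c2nc(O)n(Cc3ccccc3)c2n1`, differs from compound 1 in this way: ethyl in place of hydrogen on a saturated chain carbon, two bonds along the chain from a sulfur. That is the same kind of lengthening as the step to compound 2, carried one carbon further out, so the step to compound 2 is the one that bears on it. Going by the values given here, on that basis a lower number than for compound 1 is expected in this assay, of about the same size as the step to compound 2 or somewhat smaller, since no measured compound shows whether the gain continues past propyl. The expected step is a 10-fold lower number from compound 1 to compound 4 (1.00 log units; beyond the scatter). For compound 4 the estimate is 0.01 uM, with a range from 0.003 uM to 0.05 uM.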

Compound 4, minimum effective concentration: 0.01 uM
Compound 4: the middle estimate sits on the measured number at the digits printed; measured number inside the range.
By their numbers in this assay, from the lowest: compounds 2 and 4 (each within the scatter of the next); then compound 1; then compound 3.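

Working notes on the chain on sulfur, read in this assay: the gain over the ethylsulfanyl chain is not confined to propyl, since the ethyl in place of hydrogen, on a saturated chain carbon two bonds along the chain from a sulfur, gives a 10-fold lower number from compound 1 to compound 4 (1.00 log units; beyond the scatter). The further methyl, on a saturated chain carbon three bonds along the chain from a sulfur, gives no change at the digits printed from compound 2 to compound 4 (within the scatter), so this place accepts the ethyl to butyl lengthening while the added carbon brings no gain beyond that of propyl; among these three compounds, the chain-length effect is thus a single drop followed by a level stretch, and no compound here goes against that reading. Nothing on record accounts for this shape.

Still open, going by these compounds, is whether a longer chain such as pentyl or hexyl keeps the number of the butylsulfanyl compound, and whether a branched chain such as isobutyl, or a chain ending in an amine or a carboxylic acid, is accepted at the same place. For the compounds shown here, also open is what a chlorobenzyl group would do on the butylsulfanyl compound, as the only chlorobenzyl compound here differs from the others in more than one place.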